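The source may report more compounds than this note shows. Statements on the series, on what has been measured and on what is new or still open speak of the compounds shown alone.

Of the compounds shown here, three have numbers so far. In a physicochemical assay for lipophilicity (on this read-out lower numbers stand for lower lipophilicity and higher numbers for higher lipophilicity), compound 1 (`CC#CCn1c(N2CCC[C@@H](N)C2)cc(=O)n(Cc2cc(Br)c(OC)c(OC)c2)c1=O`) gives 2.38 and compound 2 (`CC#CCn1c(N2CCC[C@@H](N)C2)cc(=O)n(Cc2cc(OC)c(OC)c(Br)c2Br)c1=O`) gives 3.21 on this scale. Compound 3 (`COc1cc(Cn2c(=O)cc(N3CCC[C@@H](N)C3)n(Cc3cc(F)ccc3C#N)c2=O)cc(Br)c1OC`) gives 3.49 here, with compound 2 within the scatter of it and compound 1 beyond the scatter.

Compound 4 (`N#Cc1ccc(F)cc1Cn1c(N2CCC[C@@H](N)C2)cc(=O)n(Cc2cc(F)cc(F)c2)c1=O`) has no number yet. The change from compound 3 is 3,5-difluorophenyl in place of 3-bromo-4,5-dimethoxyphenyl on a saturated chain carbon bound to an aromatic nitrogen, that is, 3-bromo-4,5-dimethoxybenzyl to 3,5-difluorobenzyl.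

The step of a number 1.11 log units higher from compound 1 to compound 3 (beyond the scatter) is large, but it concerns 2-cyano-5-fluorophenyl, which compound 4 carries as well, so it gives no direct guide here. The closest guide is a number 0.83 log units higher from compound 1 to compound 2 (beyond the scatter), a modest step for bromo in place of hydrogen on an aromatic carbon. Compound 4 has no bromo, so a modest shift in the opposite direction is the starting expectation. Among the compounds with values here, no measured compound shows the exchange of the two methoxy groups for the two fluoro groups, and that gap widens the range.

The expected step in this assay is a number 0.49 log units lower from compound 3 to compound 4 (beyond the scatter), modest and downward. For compound 4 the estimated value is 3, with an expected range of 2.5 to 3.5.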

Compound 4, partition coefficient: 3.23
Beside the measured number, compound 4's estimate is 0.23 log units below it; the measured number falls inside the stated range.
By their numbers in this assay, from the lowest: compound 1; then compounds 2, 4 and 3 (each within the scatter of the next).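

Replacing 3-bromo-4,5-dimethoxyphenyl with 3,5-difluorophenyl on a saturated chain carbon bound to an aromatic nitrogen gives, in this assay, a number 0.26 log units lower from compound 3 to compound 4 (within the scatter), although the group goes from 11 heavy atoms to 8 and from 2 hydrogen-bond acceptors to 0. Within the data shown here, this is the first whole-group exchange at this place; the earlier step at this group, bromo in place of hydrogen on an aromatic carbon, was a single-atom change and gave a number 0.83 log units higher from compound 1 to compound 2 (beyond the scatter), so a single change on this group can exceed the scatter while this larger exchange does not. Nothing at hand explains why this exchange stays within the scatter.

The contributions of the bromo, the two methoxy groups and the two fluoro groups remain unseparated, since all of them change in one step and no compound shown carries only one of these sets on the benzyl group. Also open, from the compounds shown here alone, is how this assay responds at this place to a group of another kind, such as a carboxylic acid or a primary amine on the aromatic ring.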